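Swapping the terminal group on the piperazine nitrogen

The source may report more compounds than this note shows. Statements on the series, on what has been measured and on what is new or still open speak of the compounds shown alone.

Measured so far:
compound 1 `COc1ccc(Oc2ccccc2-c2ccsc2S(=O)(=O)N2CCN(C(=S)Nc3ccc([N+](=O)[O-])cc3)CC2)cc1OC`: 16%
compound 2 `COc1ccc(Oc2ccc([N+](=O)[O-])cc2-c2ccsc2S(=O)(=O)N2CCN(C(=S)Nc3ccc([N+](=O)[O-])cc3)CC2)cc1OC`: 16%
compound 3 `COc1ccc(Oc2ccccc2-c2ccsc2S(=O)(=O)N2CCN(C(=O)Nc3cc(C(F)(F)F)cc(C(F)(F)F)c3)CC2)cc1OC`: 23%

All three were tested in an assay for binding affinity to Apoptosis regulator Bcl-2 (Homo sapiens), read by fluorescence polarization, with stated times of 30 min and 20 min, tested at 100 uM; a higher number here means more inhibition at the concentration tested (going by the name of the read-out), a lower number less inhibition. Compound 1 sits level with compound 2 at the digits shown, and the two together are the lowest of the three numbers; compound 3 lies a little higher, but that gap is within the scatter. For the measured compounds named here, the single one-place step measured, no change at the digits printed from compound 1 to compound 2 (within the scatter), concerns a different part of the molecule and does not touch the group that changes here.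

Compound 4 `COc1ccc(Oc2ccccc2-c2ccsc2S(=O)(=O)N2CCN(C(=O)Nc3ccc(F)cc3)CC2)cc1OC` differs from compound 1 by a group of 10 heavy atoms (7 carbon, 1 nitrogen, 1 oxygen, 1 fluorine; one six-membered aromatic ring of carbon only) in place of a group of 12 heavy atoms (7 carbon, 2 nitrogen, 2 oxygen, 1 sulfur; one six-membered aromatic ring of carbon only), on an amine nitrogen in a ring. Going by the values given here, no measured step covers this change. Compound 3, which carries a related (carbamoyl) group, gives 23%, which is within the scatter of compound 1. The step from compound 1 to compound 4 is therefore expected to be small, a number 2 percentage points higher from compound 1 to compound 4 (within the scatter), with no clear direction. Compound 4 is estimated at 18%, in the range 8% to 30%.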

Compound 4, a percentage reported as inhibition, at one concentration (the size of the read-out at that concentration, not a potency): 15%
The estimate for compound 4 lay 3 percentage points above the measured number; measured number inside the range.
By their numbers in this assay, from the lowest: compounds 4, 1, 2 and 3 (each within the scatter of the next).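

Putting (4-fluorophenyl)carbamoyl on the amine nitrogen in a ring, in place of the larger sulfur-containing group, barely registers in this assay (a number 1 percentage points lower from compound 1 to compound 4 (within the scatter)). For the compounds shown here, this is the first measured step at this position, and it shows that this exchange of terminal groups does not separate the two compounds in this test. Nothing measured here explains the result.

From the compounds shown here alone, it remains open whether any change at this nitrogen can move the number. A terminal group without an aromatic ring, such as a short chain ending in an amine or a carboxylic acid, would test that.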